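A few compounds are considered here, and "the series" means these few. Any claim that something is new, unique, unknown or untested is made for them only; others in the source may bear on it.

Within the data shown here, only two compounds sharing this core have been measured so far in a functional assay on K562 cells (Homo sapiens) for cytotoxicity; a lower number here means a stronger inhibitor, a higher number a weaker inhibitor. Compound 1 `CCC(CO)Nc1nc(NCc2ccccc2)c2nc(Br)n(C(C)C)c2n1` gives 27000 nM, while compound 2 `CCC(CO)Nc1nc(NCc2ccccc2)c2nc([N+](=O)[O-])n(C(C)C)c2n1` gives 117000 nM, the higher of the two numbers and therefore the weaker result. Compound 3 `CCCOc1nc2c(NCc3ccccc3)nc(NC(CC)CO)nc2n1C(C)C` keeps the core and changes one group: propoxy in place of nitro on an aromatic carbon. In words, it has propoxy in place of nitro on an aromatic carbon, the same carbon that bears bromo in compound 1. Among the measured compounds shown here, one measured step bears on this carbon: a 4.3-fold higher number from compound 1 to compound 2 (0.64 log units; beyond the scatter), a modest change beyond the scatter. For the measured compounds named here, no compound with propoxy has been measured, so the direction remains uncertain. Removing nitro is nevertheless expected to give a modest move towards a lower number, no larger than that earlier step. The expected change is a 2.1-fold lower number from compound 2 to compound 3 (0.33 log units; beyond the scatter). The estimate for compound 3 is 55000 nM, with an expected range from 18000 nM to 150000 nM.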

Compound 3, half-maximal inhibitory concentration: 20000 nM
Beside the measured number, compound 3's estimate is 2.8-fold (0.44 log units) above it, and the stated range covers the measured number.
By their numbers in this assay, from the lowest: compounds 3 and 1 (each within the scatter of the next); then compound 2.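

Replacing nitro with propoxy on this carbon, which lies between two ring nitrogen atoms, restores activity in this assay (a 5.9-fold lower number from compound 2 to compound 3 (0.77 log units; beyond the scatter)). This shows that a group of several atoms can sit here without a loss compared with a single bromo atom (a 1.4-fold lower number from compound 1 to compound 3 (0.13 log units; within the scatter)), so bromo and propoxy cannot be told apart in this assay, while nitro stands apart from both. Nothing measured here explains why nitro differs from the other two groups.

As far as these compounds go, it remains open whether any group on this carbon can bring the number well below those of compound 1 and compound 3, as an amine, a carboxylic acid or a longer chain might or might not. It is also unclear whether the result for propoxy depends on its oxygen or on its chain, which a comparison with methoxy or a plain propyl group would help to separate.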